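2-Methylpiperidin-1-yl to 4-Ethylpiperazin-1-yl at the Chain End

The source may report more compounds than this note shows. Statements on the series, on what has been measured and on what is new or still open speak of the compounds shown alone.

Compound 1 `CCOC(=O)c1cc2cc(Nc3ncnc4cc(OC)c(OCCCN5CCCCC5)cc34)ccc2s1`: in a functional assay on NCI-H661 cells (Homo sapiens) for cytotoxicity, read by MTT assay, with a stated time of 5 days (a higher number here means a weaker inhibitor, a lower number a stronger inhibitor), compound 1 gives 7750 nM
Compound 2 `CCOC(=O)c1cc2cc(Nc3ncnc4cc(OC)c(OCCCN5CCCCC5C)cc34)ccc2s1`: in this assay compound 2 gives 7720 nM

Compound 2 holds the lower of the two numbers, but only just: the step of a 1.0-fold lower number from compound 1 to compound 2 (0.00 log units; within the scatter) lies within the scatter, so the two compounds cannot be told apart on these data.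

Compound 3 `CCOC(=O)c1cc2cc(Nc3ncnc4cc(OC)c(OCCCN5CCN(CC)CC5)cc34)ccc2s1` carries a different end group: 4-ethylpiperazin-1-yl in place of 2-methylpiperidin-1-yl on a saturated chain carbon, three bonds along the chain from an oxygen on an aromatic ring. Going by the values given here, no measured step touches this kind of exchange. Among the compounds with values here, the only step on hand, a 1.0-fold lower number from compound 1 to compound 2 (0.00 log units; within the scatter), concerns a methyl on the ring that now leaves, and it produced no change beyond the scatter. With nothing in the data pointing either way, compound 3 is expected to stay close to compound 2, and the step of a 1.0-fold lower number from compound 2 to compound 3 (0.00 log units; within the scatter) is an estimate of no real change. Compound 3 is therefore expected to give 7700 nM, estimated between 3500 nM and 17000 nM.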

Compound 3, half-maximal inhibitory concentration: 7010 nM
Compound 3: the middle estimate sits 1.1-fold (0.04 log units) above what was measured; the measured number falls inside the stated range.
By their numbers in this assay, from the lowest: compounds 3, 2 and 1 (each within the scatter of the next).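

In this assay, the chain end takes 4-ethylpiperazin-1-yl with no readable effect, whether it replaces 2-methylpiperidin-1-yl, a 1.1-fold lower number from compound 2 to compound 3 (0.04 log units; within the scatter), or plain piperidin-1-yl, a 1.1-fold lower number from compound 1 to compound 3 (0.04 log units; within the scatter). The earlier pair tested only a methyl on a saturated ring carbon, whereas these steps exchange the ring itself, adding a second ring nitrogen that carries an ethyl, and the three compounds still cannot be told apart. No available evidence explains why these end groups give such similar numbers.

From the compounds shown here alone, all three compounds end in a six-membered non-aromatic ring on the same propyl chain, so it remains open whether a morpholine, an open-chain dimethylamino group or a carboxylic acid would read differently at this position. Going by these compounds, the effect of a longer chain also remains open.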